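A Methyl Step Repeated on a Shorter Chain

The source may report more compounds than this note shows. Statements on the series, on what has been measured and on what is new or still open speak of the compounds shown alone.

Measured so far in a functional assay on the whole organism with Rattus norvegicus as the target, at a dose of 100 mg/kg; a lower number here means less inhibition, a higher number more inhibition at the dose given (going by the name of the read-out):
Compound 1, `CC/N=C(/NC#N)NCCCCn1nc(-c2ccccc2)ccc1=O`, 58.8%
Compound 2, `CC/N=C(/NC#N)NCCCn1nc(-c2ccccc2)ccc1=O`, 62.9%
Compound 3, `CCC/N=C(/NC#N)NCCCCn1nc(-c2ccccc2)ccc1=O`, 26.3%

Compound 1 and compound 2 lie within the usual scatter of each other in this assay, so no order between them is claimed; the difference between their two cores is not broken down here. Compound 3 carries one change against compound 1, (methyl in place of hydrogen on a saturated chain carbon, two bonds along the chain from a double-bonded nitrogen), and this change brings a number 32.5 percentage points lower from compound 1 to compound 3 (beyond the scatter).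

Compound 4, `CCC/N=C(/NC#N)NCCCn1nc(-c2ccccc2)ccc1=O`, is not yet measured. It stands to compound 2 as compound 3 stands to compound 1: the change is methyl in place of hydrogen on a saturated chain carbon, two bonds along the chain from a double-bonded nitrogen, the same change at the same place, now made on the core of compound 2.

Within the data shown here, with only one earlier instance of this change, the expectation for compound 4 rests on compound 3 and its step of a number 32.5 percentage points lower from compound 1 to compound 3 (beyond the scatter). Compound 4 is therefore expected to fall by about a number 31.9 percentage points lower from compound 2 to compound 4 (beyond the scatter). For compound 4 in this assay a value of about 31% is estimated. The estimate for compound 4 is expected to lie between 12% and 50%.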

Compound 4, a percentage reported as inhibition, in the whole organism at one dose (the size of the read-out at that dose, not a potency): 52.9%
For compound 4 the middle estimate is 21.9 percentage points below the measured one; measured number above the stated range.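

In this assay, the methyl in place of hydrogen on the core of compound 2 gives a number 10 percentage points lower from compound 2 to compound 4 (within the scatter), so on this core the change has no effect that can be told from the scatter. The same change therefore does not carry over from one core to the other at the same size: the same change on two cores in this assay, a number 32.5 percentage points lower (beyond the scatter) from compound 1 to compound 3 and a number 10 percentage points lower (within the scatter) from compound 2 to compound 4, 22.5 percentage points apart, beyond the scatter of two such steps This shows that the large step seen on the core of compound 1 cannot simply be transferred within this series, but it does not show why the two cores differ, and two pairs cannot say how the change would behave on any further core.

The compounds shown leave open what a longer chain, such as butyl, or a branched chain such as isopropyl, would do at the same place on either core. They also leave open whether the gap between the two cores would persist with those groups, or with a substituent such as chlorine on the phenyl ring.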